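The compounds below may be only part of what the source reports. "The series", "measured", "known", "first", "only" and "open" are said of these compounds alone.

Working notes on a shared core, seen here in `O=C(Nc1ccc(Cl)c(-c2nnc3c(Cl)cccn23)c1)c1ccccc1` as compound 2, all compared in a functional assay on A549 cells (Homo sapiens) for antiproliferative activity, read by MTT assay, with a stated time of 72 h; on this read-out lower numbers stand for stronger inhibition and higher numbers for weaker inhibition. Compound 1, `CS(=O)(=O)c1ccc(C(=O)Nc2ccc(Cl)c(-c3nnc4c(Cl)cccn34)c2)c(Cl)c1`, sits at the limit of > 100000 nM in this assay, at which 1 of the 3 values shown sits. In this assay compound 1 gives only the limit > 100000 nM. Compound 2 gives 76900 nM, the highest of the two numbers shown. Compound 3, `O=C(Nc1ccc(Cl)c(-c2nnc3c(Cl)cccn23)c1)c1ccc(Cl)cc1Cl`, gives 61300 nM. The step of a 1.3-fold lower number from compound 2 to compound 3 (0.10 log units; within the scatter) stays within the scatter, and an at least 1.6-fold lower number from compound 1 to compound 3 (0.21 log units; that floor lies within the scatter) is a floor that also lies within the scatter. Compound 4, `O=C(Nc1ccc(Cl)c(-c2nnc3c(Cl)cccn23)c1)c1ccc(F)cc1Cl`, differs from compound 2 by 2-chloro-4-fluorophenyl in place of phenyl on a carbonyl carbon. For the measured compounds named here, the one measured step at the same carbonyl carbon, a 1.3-fold lower number from compound 2 to compound 3 (0.10 log units; within the scatter), gives no ground to expect movement beyond the scatter in this assay. Compound 4 is therefore estimated at 70000 nM, with a range of 30000 nM to 160000 nM. An expected step of a 1.1-fold lower number from compound 2 to compound 4 (0.04 log units; within the scatter) follows.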

Compound 4, half-maximal inhibitory concentration: > 100000 nM
Compound 4 was reported as a limit; the forecaster's own chance of this, stated with the estimate: 25%; middle value at least 1.4-fold (0.15 log units) from the limit.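

At the carbonyl carbon, 2-chloro-4-fluorophenyl in place of phenyl (an at least 1.3-fold higher number from compound 2 to compound 4 (0.11 log units; that floor lies within the scatter)) and fluoro in place of chloro on an aromatic carbon (an at least 1.6-fold higher number from compound 3 to compound 4 (0.21 log units; that floor lies within the scatter)) both give floors within the scatter, so neither change is shown to move the number in this assay. Together with compound 3, compound 4 makes two halogenated rings at this carbon with no step from compound 2 printed beyond the scatter. The step from compound 1 to compound 4 cannot be read, since both values are limits: the limit of > 100000 nM in this assay, at which 2 of the 4 values shown sit.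

Open, as far as these compounds go, is whether an amine or a carboxylic acid on this ring, or a longer chain in its place, would move the number beyond the scatter.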